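The compounds below may be only part of what the source reports. "The series", "measured", "known", "first", "only" and "open" are said of these compounds alone.

Measured so far in a functional assay on HEK293 cells with D(4) dopamine receptor (Homo sapiens) as the target, read by FLIPR; on this read-out lower numbers stand for an effect already at smaller amounts and higher numbers for an effect only at larger amounts of compound:
compound 1 `CCO/N=C(\CCN1CCN(c2ccccc2)CC1)c1ccccc1`, compound 1 gives 109 nM;
compound 2 `CCO/N=C(\CCN1CCN(c2ccccc2OC)CC1)c1ccccc1`, compound 2 gives 338 nM;
compound 3 `CCO/N=C(\CCN1CCN(c2cccc(OCC)c2)CC1)c1ccccc1`, compound 3 gives 347 nM.

Compound 3 stands at the highest number of the three. Its value and that of compound 2 lie within the scatter of each other, as a 1.0-fold higher number from compound 2 to compound 3 (0.01 log units; within the scatter) shows, whereas a 3.2-fold higher number from compound 1 to compound 3 (0.50 log units; beyond the scatter) lies beyond it, as does a 3.1-fold higher number from compound 1 to compound 2 (0.49 log units; beyond the scatter).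

Compound 4 `CCO/N=C(\CCN1CCN(c2ncccn2)CC1)c1ccccc1` differs from compound 3 in one place: pyrimidin-2-yl in place of 3-ethoxyphenyl on an amine nitrogen in a ring. Among the compounds with values here, none of the measured steps makes exactly this change. The nearest guide is a 3.2-fold higher number from compound 1 to compound 3 (0.50 log units; beyond the scatter) read backwards: compound 1, which carries no ethoxy on its ring, shows the lower number, and compound 4 likewise carries no ethoxy. Yet the ring itself also changes, from a six-membered aromatic ring of carbon only to a six-membered aromatic ring with 2 hetero atoms, and no measured pair shows what that does in this assay. The expectation is therefore a modest step to a lower number, a 1.7-fold lower number from compound 3 to compound 4 (0.24 log units; within the scatter), held with wide uncertainty. Compound 4 is estimated at 200 nM, with a range from 50 nM to 800 nM.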

Compound 4, half-maximal effective concentration: 615 nM
For compound 4 the middle estimate is 3.1-fold (0.49 log units) below the measured one, and the stated range covers the measured number.
By their numbers in this assay, from the lowest: compound 1; then compounds 2, 3 and 4 (each within the scatter of the next).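

In this assay, within the data shown here, this is the first change that replaces atoms of the aromatic ring on the amine nitrogen itself, rather than adding a group to that ring, and measured against the plain phenyl of compound 1 it shows a 5.6-fold higher number from compound 1 to compound 4 (0.75 log units; beyond the scatter) as a result. Measured against the two substituted rings, the same position gives no difference that can be told apart from the usual scatter, with a 1.8-fold higher number from compound 3 to compound 4 (0.25 log units; within the scatter) and a 1.8-fold higher number from compound 2 to compound 4 (0.26 log units; within the scatter) as the steps. Among these four compounds, then, only compound 1 stands apart, while 2-methoxyphenyl, 3-ethoxyphenyl and pyrimidin-2-yl fall together even though pyrimidin-2-yl has fewer heavy atoms, two ring nitrogens and no oxygen.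

Nothing available explains why these three different rings end up together. From the compounds shown here alone, it remains open whether a single ring nitrogen, as in pyridin-2-yl, would stay close to compound 1 or join compounds 2, 3 and 4, and whether an amine or a carboxylic acid on the phenyl ring would behave like methoxy and ethoxy.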